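The compounds below may be only part of what the source reports. "The series", "measured", "known", "first", "only" and "open" are said of these compounds alone.

Measured so far in a functional assay on the whole organism (strain Wistar) for inhibition, with Rattus norvegicus as the target, read by paw edema, with a stated time of 4 h, at a dose of 100 mg/kg; on this read-out higher numbers stand for more inhibition at the one dose given (going by the name of the read-out) and lower numbers for less inhibition:
compound 1 `COc1cc2c(cc1OC)C(CC(=O)Nc1cccc(Cl)c1)CC2` gives 25.8%
compound 2 `COc1cc2c(cc1OC)C(CC(=O)Nc1ccc(Br)cc1)CC2` gives 40.6%
compound 3 `COc1cc2c(cc1OC)C(CC(=O)Nc1ccccn1)CC2` gives 29.7%

Compound 2 stands highest of the three on this read-out: the gaps a number 14.8 percentage points higher from compound 1 to compound 2 (beyond the scatter) and a number 10.9 percentage points lower from compound 2 to compound 3 (beyond the scatter) both lie beyond the scatter, while a number 3.9 percentage points higher from compound 1 to compound 3 (within the scatter) does not.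

Compound 4 `COc1cc2c(cc1OC)C(CC(=O)Nc1cccnc1)CC2` differs from compound 2 in one place: pyridin-3-yl in place of 4-bromophenyl on an amide-type nitrogen. The step that bears most on this change is a number 10.9 percentage points lower from compound 2 to compound 3 (beyond the scatter), where pyridin-2-yl took the place of 4-bromophenyl on the same amide-type nitrogen and the inhibition fell by a modest amount. A drop of similar size in this assay is therefore expected here. Compound 4 is estimated at 30%, with a range from 18% to 42%, which corresponds to an expected step of a number 10.6 percentage points lower from compound 2 to compound 4 (beyond the scatter).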

Compound 4, a percentage reported as inhibition, in the whole organism at one dose (the size of the read-out at that dose, not a potency): 34.4%
Compound 4: the middle estimate sits 4.4 percentage points below what was measured, within the range that was stated.
By their numbers in this assay, from the lowest: compounds 1, 3, 4 and 2 (each within the scatter of the next, the first and the last beyond it).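

In this assay the pyridin-3-yl group on the amide-type nitrogen gives a number 6.2 percentage points lower from compound 2 to compound 4 (within the scatter) and so, unlike pyridin-2-yl, stays within the scatter of 4-bromophenyl. The steps of a number 4.7 percentage points higher from compound 3 to compound 4 (within the scatter) and a number 8.6 percentage points higher from compound 1 to compound 4 (within the scatter) also stay within it, so compound 4 cannot be told apart from any of the other three compounds on this read-out. Nothing given here accounts for these numbers. The compounds shown leave open how an unsubstituted phenyl or a cyclohexyl on the same amide-type nitrogen would read.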